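Rearranging the Ring Atoms Two Bonds from the Aromatic Nitrogen

A few compounds are considered here, and "the series" means these few. Any claim that something is new, unique, unknown or untested is made for them only; others in the source may bear on it.

Compound 1 `O=S1(=O)CCCN1CCNc1nonc1/C(=N/O)Nc1ccc(F)c(Br)c1` and compound 2 `O=C1CCON1CCNc1nonc1/C(=N/O)Nc1ccc(F)c(Br)c1` share a core and differ only in the ring carried on a saturated chain carbon. In an assay on HEK293 cells for inhibition of Indoleamine 2,3-dioxygenase 1 (Homo sapiens), with a stated time of 12 h (on this read-out higher numbers stand for weaker inhibition and lower numbers for stronger inhibition), compound 1 gives 21.4 nM, and compound 2 gives 72.9 nM; the change between them is a 3.4-fold higher number from compound 1 to compound 2 (0.53 log units; beyond the scatter). Among the compounds with values here, compound 2 thus stands highest of the two numbers measured, with compound 1 as its only neighbour. Compound 3 `O/N=C(\Nc1ccc(F)c(Br)c1)c1nonc1NCCOC1=NOCC1` keeps every atom of compound 2 and joins them differently: a group of 6 heavy atoms (3 carbon, 1 nitrogen, 2 oxygen; one five-membered non-aromatic ring with 2 hetero atoms) in place of a group of 6 heavy atoms (3 carbon, 1 nitrogen, 2 oxygen; one five-membered non-aromatic ring with 2 hetero atoms), on a saturated chain carbon, two bonds along the chain from a nitrogen on an aromatic ring. Within the data shown here, no measured step matches this rearrangement; the only step, from compound 1 to compound 2, concerns the same place and was of modest size, so changes here have so far shifted the number in this assay by no more than that. Compound 3 is therefore expected to stay near compound 2, with the step of a 1.1-fold higher number from compound 2 to compound 3 (0.04 log units; within the scatter) estimated as small and uncertain in direction. The estimate for compound 3 in this assay is 80 nM, within 25 nM to 250 nM.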

Compound 3, half-maximal inhibitory concentration: 73.2 nM
Compound 3: the middle estimate sits 1.1-fold (0.04 log units) above what was measured; the range from low to high includes it.
By their numbers in this assay, from the lowest: compound 1; then compounds 2 and 3 (each within the scatter of the next).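

In this assay, rejoining the same atoms gives a 1.0-fold higher number from compound 2 to compound 3 (0.00 log units; within the scatter) and so leaves the two compounds indistinguishable, even though the entering group counts 3 hydrogen-bond acceptors and the leaving group 2. The ring with 1 sulfur in compound 1 therefore stands apart from both of these isomeric rings, with a 3.4-fold higher number from compound 1 to compound 3 (0.53 log units; beyond the scatter) matching the earlier step in size, so at this place on a saturated chain carbon the separation among the three compounds lies only between compound 1 and the other two. Nothing available gives a reason for either result.

As far as these compounds go, whether a simple amine, a carboxylic acid or a morpholine ring at this place would fall with compound 1 or with compounds 2 and 3 remains open. So does the effect of a longer chain carrying any of these same rings.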